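Cyclopropyl in Place of Cyano: An Expected Lipophilicity Shift

The compounds below may be only part of what the source reports. "The series", "measured", "known", "first", "only" and "open" are said of these compounds alone.

Compound 1 `C[C@H](Oc1ccc(NC(=O)CC(N)=O)c(C2CC2)n1)c1c(Cl)ccc(F)c1Cl` — 3.7
Compound 2 `C[C@H](Oc1ccc2ncc(/C=C/C(=O)O)c(C#N)c2c1)c1c(Cl)ccc(F)c1Cl` — 2.3

Both compounds were measured in a physicochemical assay for lipophilicity, using the shake flask method; on this read-out higher numbers stand for higher lipophilicity and lower numbers for lower lipophilicity. Compound 1 gives 3.7 in this assay, while compound 2 gives 2.3. Compound 2 thus holds the lower of the two numbers, with compound 1 standing higher by a difference that goes beyond the usual scatter of such measurements. Compound 3 `C[C@H](Oc1ccc2ncc(/C=C/C(=O)O)c(C3CC3)c2c1)c1c(Cl)ccc(F)c1Cl` has not yet been measured in this assay. It differs from compound 2 in one place: cyclopropyl in place of cyano on an aromatic carbon. Among the compounds with values here, since no stepwise pair among the measured compounds covers this change, the expectation rests on the structural change itself and on where compound 2 stands. The step from compound 2 to compound 3 is expected to be upward, with a size of a number 0.80 log units higher from compound 2 to compound 3 (beyond the scatter). Compound 3 is therefore estimated at 3.1, within a range from 2.5 to 3.7.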

Compound 3, distribution coefficient: 4.1
Beside the measured number, compound 3's estimate is 1.00 log units below it; measured number outside the range, above it.
By their numbers in this assay, from the lowest: compound 2; then compound 1; then compound 3.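

On an aromatic carbon opposite the ring nitrogen and ortho to the 2-carboxyethenyl group, cyclopropyl in place of cyano gives a number 1.80 log units higher from compound 2 to compound 3 (beyond the scatter) in this assay, a step the data class as large. Within the data shown here, this is the first pair that differs in one place, and it shows that a single exchange at this position, with one hydrogen-bond acceptor leaving and a three-membered carbon ring entering, is enough to move this read-out well past the scatter. No measurement shown here accounts for the size of the step.

As far as these compounds go, it remains open whether other groups at this position, such as a methyl, an amine or a longer alkyl chain, would give a step of similar size. From the compounds shown here alone, it is equally open whether the same exchange would give a similar step with a carboxylic acid in place of the 2-carboxyethenyl group.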